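A few compounds are considered here, and "the series" means these few. Any claim that something is new, unique, unknown or untested is made for them only; others in the source may bear on it.

Of the compounds shown here, three built on one shared core have been measured so far, and they differ only in the group attached to an amine nitrogen in a ring. Compound 1 `COc1ccc(-c2cnc3nc(N)nc(N4CCN(C(=O)COc5ccccc5)CC4)c3n2)cc1OC` carries a (phenoxymethyl)carbonyl there, and in a functional assay on cells (T-cell, Homo sapiens) for inhibition (on this read-out higher numbers stand for weaker inhibition and lower numbers for stronger inhibition), compound 1 gives 4 nM. Compound 2 `COc1ccc(-c2cnc3nc(N)nc(N4CCN(C(=O)c5ccccc5)CC4)c3n2)cc1OC` carries a benzoyl instead, and in this assay compound 2 gives 400 nM. Compound 3 `COc1ccc(-c2cnc3nc(N)nc(N4CCN(c5ccc(F)cc5)CC4)c3n2)cc1OC` carries a 4-fluorophenyl, and in this assay compound 3 gives 100 nM. Among these three numbers compound 3 stands second highest: the step from compound 2 is a 4.0-fold lower number from compound 2 to compound 3 (0.60 log units; beyond the scatter), while the step from compound 1 is a 25-fold higher number from compound 1 to compound 3 (1.40 log units; beyond the scatter).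

Compound 4 `COc1ccc(-c2cnc3nc(N)nc(N4CCN(Cc5ccc(C(C)(C)C)cc5)CC4)c3n2)cc1OC` is the next variation at the same ring nitrogen: 4-(tert-butyl)benzyl in place of 4-fluorophenyl on an amine nitrogen in a ring. Among the measured compounds shown here, no measured pair tests a benzyl group against an aryl group directly, so the expectation rests on loose hints. The two measured steps that touch compound 3, a 4.0-fold lower number from compound 2 to compound 3 (0.60 log units; beyond the scatter) and a 25-fold higher number from compound 1 to compound 3 (1.40 log units; beyond the scatter), show that this position moves the number a great deal. The lowest number belongs to compound 1 with 4 nM, whose ring nitrogen carries the (phenoxymethyl)carbonyl, a group of more than one piece. Compound 4 also carries a group of more than one piece, a benzyl bearing a tert-butyl, so a modest move toward lower numbers is expected, with wide uncertainty. The step expected from this change is a 2.5-fold lower number from compound 3 to compound 4 (0.40 log units; beyond the scatter). For compound 4 in this assay the estimate is 40 nM, ranging from 5 nM to 300 nM.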

Compound 4, half-maximal inhibitory concentration: 4300 nM
The estimate for compound 4 lay 110-fold (2.03 log units) below the measured number; the measured number lies above the stated range.
By their numbers in this assay, from the lowest: compound 1; then compound 3; then compound 2; then compound 4.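

In this assay, a large group on the ring nitrogen does not by itself give a low number: the 4-(tert-butyl)benzyl of compound 4 gives the highest number of the four, with a 43-fold higher number from compound 3 to compound 4 (1.63 log units; beyond the scatter) and an 11-fold higher number from compound 2 to compound 4 (1.03 log units; beyond the scatter). The spread at this one position now reaches a 1100-fold higher number from compound 1 to compound 4 (3.03 log units; beyond the scatter), so the choice of group here can separate strong inhibition from weak inhibition, and a change from an aryl group to a benzyl group bearing a tert-butyl lies on the weak side in this set. That step replaces the fluorine with a tert-butyl and also adds the benzyl carbon, so the two changes cannot be told apart, and nothing available explains the rise in the number.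

A plain benzyl or a 4-fluorobenzyl on the same nitrogen would show whether the benzyl link or the tert-butyl accounts for more of the rise. From the compounds shown here alone, it also remains open whether an amine or a carboxylic acid on the benzyl ring, or a longer chain in place of the benzyl carbon, would bring the number back down.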